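One number to go on for compound 4

The source may hold more compounds than are shown below. What is called first, only, known or untested is meant among the compounds shown, and "the series" means these compounds.

Values measured in an ADME assay on Vero cells (Chlorocebus sabaeus) for cytotoxicity, read by CellTiter-Glo, with a stated time of 72 h (on this read-out lower numbers stand for higher toxicity in this test and higher numbers for lower toxicity in this test), follow here:
Compound 1 `CSc1c(C)[n+]([O-])c2ccccc2[n+]1[O-]` gives > 16 ug/mL as a limit, not a number
Compound 2 `Cc1c(N2CCCC2)[n+]([O-])c2ccccc2[n+]1[O-]` gives > 16 ug/mL as a limit, not a number
Compound 3 `[O-][n+]1nc(NC2CC2)[n+]([O-])c2ccccc21` gives 21 ug/mL as a true number

Among the compounds with values here, compound 3 holds the only true number, 21 ug/mL on this scale. The other two results are the limit of > 16 ug/mL in this assay, at which 2 of the 3 values shown sit, and cannot be ranked against it.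

Compound 4 `COCC(C)Nc1n[n+]([O-])c2ccccc2[n+]1[O-]` carries 1-(methoxymethyl)ethyl in place of cyclopropyl on a nitrogen on an aromatic ring and has not yet been measured.

Within the data shown here, the only measured step is a step that the two limits leave unreadable from compound 1 to compound 2 and gives no size to carry over. That leaves compound 3 at 21 ug/mL as the sole anchor, with no direction favoured. In this assay the expected result is a 1.1-fold lower number from compound 3 to compound 4 (0.02 log units; within the scatter) and no step beyond the scatter. For compound 4 the estimated value is 20 ug/mL within an expected range of 9 ug/mL to 45 ug/mL and the test may report only a limit instead.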

Compound 4, half-maximal cytotoxic concentration: > 50 ug/mL
Compound 4 gave a limit, no number (the forecaster's own chance of this, stated with the estimate: 35%); middle value at least 2.5-fold (0.39 log units) from the limit.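

Placing 1-(methoxymethyl)ethyl in place of cyclopropyl on a nitrogen on an aromatic ring gives an at least 2.3-fold higher number from compound 3 to compound 4 (0.37 log units; beyond the scatter) in this assay. This is the first step among these compounds with a readable size, and it shows that the group at this place can shift the result beyond the scatter, towards lower toxicity in this test. Compound 4 gives > 50 ug/mL, which is a limit and not a number, so the step sets only a minimum size: the limit of > 50 ug/mL in this assay, at which 1 of the 4 values shown sits.

Two things change together in this step: a three-membered ring leaves and a chain with an oxygen enters, and the compounds shown do not tell which of them goes with the higher number. An isopropyl group, which has no ring and no oxygen, at the same place would help to separate the two.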